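Aromatic ring removed from the amine nitrogen: compound 4

This account rests on a few compounds, and the source may have more. Where it says the series, first, only, none or still open, it means among the compounds named here.

Measured in a functional assay on HeLa cells (Homo sapiens) for cytotoxicity, read by MTT assay, with a stated time of 48 h; a higher number here means a weaker inhibitor, a lower number a stronger inhibitor:
compound 1 `Cc1ccc(S(=O)(=O)/N=C(/CCNC2=CC(=O)c3ccccc3C2=O)Nc2ccccc2[N+](=O)[O-])cc1` gives 3310 nM
compound 2 `Cc1ccc(S(=O)(=O)/N=C(/CCNC2=CC(=O)c3ccccc3C2=O)Nc2ccc(F)c(F)c2)cc1` gives 8790 nM
compound 3 `COc1ccc(N/C(CCNC2=CC(=O)c3ccccc3C2=O)=N\S(=O)(=O)c2ccc(C)cc2)c(OC)c1` gives 67600 nM

Compound 3 stands highest of the three numbers in this assay; the steps leading to it are a 7.7-fold higher number from compound 2 to compound 3 (0.89 log units; beyond the scatter) and a 20-fold higher number from compound 1 to compound 3 (1.31 log units; beyond the scatter), both beyond the scatter, while the smallest step in the set is a 2.7-fold higher number from compound 1 to compound 2 (0.42 log units; beyond the scatter). Compound 4 `Cc1ccc(S(=O)(=O)/N=C(\N)CCNC2=CC(=O)c3ccccc3C2=O)cc1` differs from compound 3 by hydrogen in place of 2,4-dimethoxyphenyl on an amine nitrogen. Going by the values given here, no measured step takes the ring away altogether; every measured step exchanges one ring for another, and those exchanges move the number by large amounts. The direction of the removal is therefore open. Compound 4 is expected to land near the middle of the measured span, a 3.4-fold lower number from compound 3 to compound 4 (0.53 log units; beyond the scatter), with the estimate set at 20000 nM and a range from 3000 nM to 120000 nM.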

Compound 4, half-maximal inhibitory concentration: 24600 nM
The estimate for compound 4 lay 1.2-fold (0.09 log units) below the measured number; the measured number falls inside the stated range.
By their numbers in this assay, from the lowest: compound 1; then compound 2; then compound 4; then compound 3.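

In this assay, losing the ring does not give a single direction of change: the number falls on removal of 2,4-dimethoxyphenyl (a 2.7-fold lower number from compound 3 to compound 4 (0.44 log units; beyond the scatter)) but rises on removal of 3,4-difluorophenyl (a 2.8-fold higher number from compound 2 to compound 4 (0.45 log units; beyond the scatter)) and of 2-nitrophenyl (a 7.4-fold higher number from compound 1 to compound 4 (0.87 log units; beyond the scatter)). An aromatic ring on this amine nitrogen is thus not needed for a measurable number, and the effect of having one depends on the ring. No measured evidence bears on the reason for this.

From the compounds shown here alone, whether a methyl or benzyl group on this nitrogen reads like hydrogen or like the rings remains open. So does where an unsubstituted phenyl ring would fall.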